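A few compounds are considered here, and "the series" means these few. Any claim that something is new, unique, unknown or untested is made for them only; others in the source may bear on it.

Going by the values given here, in an in vitro ADME assay on microsomes (Rattus norvegicus) for metabolic stability (a higher number here means that the compound lasts longer, a lower number that the compound disappears faster), compound 1 (`CCc1nc(NC(CC)CC)c(OC)nc1-c1ccc(OC(F)F)cc1Cl`) gives 0.783 h and holds the higher of the two numbers so far. Compound 2 (`CCc1nc(-c2ccc(OC(F)F)cc2Cl)c(OC)nc1NC(CC)CC`) gives 0.283 h as the lower number, and the gap lies beyond the usual scatter. Compound 3 (`CCC(CC)Nc1nc(C)c(-c2ccc(OC(F)F)cc2Cl)nc1OC`) differs from compound 1 in one place (hydrogen in place of methyl on a saturated chain carbon bound to an aromatic carbon): hydrogen in place of methyl on a saturated chain carbon bound to an aromatic carbon, so ethyl becomes methyl. Among the compounds with values here, no measured pair shows this change, so the expectation rests only on its small size. The expected step (a 1.3-fold higher number from compound 1 to compound 3 (0.11 log units; within the scatter)) is slightly upward and stays within the scatter. Compound 3 is estimated at 1 h with a range from 0.5 h to 2 h in this measurement.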

Compound 3, half-life: 0.8 h
Compound 3: middle estimate off by 1.3-fold (0.10 log units), on the high side; the measured number falls inside the stated range.
By their numbers in this assay, from the lowest: compound 2; then compounds 1 and 3 (each within the scatter of the next).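

In this assay, swapping ethyl for methyl on this saturated chain carbon bound to an aromatic carbon gives a 1.0-fold higher number from compound 1 to compound 3 (0.01 log units; within the scatter), so the two compounds cannot be told apart. Going by these compounds alone, this is the first direct reading at this place, and it shows that removing this one carbon leaves the half-life within the usual scatter. No measurement given here offers an explanation for this result. On these data alone, whether a longer chain such as propyl, a cyclopropyl group or a trifluoromethyl group at this place would also leave the half-life unmoved remains open.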